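The source may hold more compounds than are shown below. What is called first, only, known or untested is meant among the compounds shown, and "the series" means these compounds.

Measured in a functional assay on HepG2 cells (Homo sapiens) for antiproliferative activity, read by MTT assay, with a stated time of 72 h; on this read-out higher numbers stand for weaker inhibition and lower numbers for stronger inhibition:
- compound 1 `O=C(N/N=C/c1ccc(F)cc1)Nc1ccc(Oc2ccnc3[nH]ccc23)c(F)c1`: 3880 nM
- compound 2 `O=C(N/N=C/c1cccc([N+](=O)[O-])c1)Nc1ccc(Oc2ccnc3[nH]ccc23)c(F)c1`: 5180 nM
- compound 3 `O=C(N/N=C/c1cccc(Cl)c1Cl)Nc1ccc(Oc2ccnc3[nH]ccc23)c(F)c1`: "not active" (no number reported)

Going by the values given here, compound 3 has no single number, so no step can be counted from it. Compound 4 `O=C(N/N=C/c1ccc(O)cc1O)Nc1ccc(Oc2ccnc3[nH]ccc23)c(F)c1` differs from it by 2,4-dihydroxyphenyl in place of 2,3-dichlorophenyl on a carbon with a double bond to nitrogen, which places 2,4-dihydroxyphenyl in place of 2,3-dichlorophenyl on a carbon with a double bond to nitrogen. Among the compounds with values here, only one measured step bears on this. The step of a 1.3-fold higher number from compound 1 to compound 2 (0.13 log units; within the scatter) changes the group at that same carbon and stays within the scatter. No step size can therefore be expected in this assay. If compound 4 gives a number at all, it is expected to lie near those of the two compounds with values. For compound 4 the estimated value is 5000 nM, with an expected range of 1800 nM to 14000 nM.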

Compound 4, half-maximal inhibitory concentration: 4550 nM
Estimate against measurement, compound 4: 1.1-fold (0.04 log units) above, and the stated range covers the measured number.
By their numbers in this assay, from the lowest: compounds 1, 4 and 2 (each within the scatter of the next).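

In this assay, compound 4 shows that 2,4-dihydroxyphenyl on this carbon gives a measurable number, and both new steps stay within the scatter (a 1.1-fold lower number from compound 2 to compound 4 (0.06 log units; within the scatter)) (a 1.2-fold higher number from compound 1 to compound 4 (0.07 log units; within the scatter)). Three differently substituted phenyl groups, one of them with hydrogen-bond donors, therefore give no separable numbers here, while steps involving compound 3 cannot be read. No measurement at hand explains this.

Still open is why 2,3-dichlorophenyl alone gives no number. Also open, on these data alone, is how a phenyl group carrying an amine or a carboxylic acid would behave here.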